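This account rests on a few compounds, and the source may have more. Where it says the series, first, only, none or still open, it means among the compounds named here.

Measured compounds:
- compound 1, `COc1ccc(/C=C(/F)c2cc(OC)c(OC)c(OC)c2)cc1O`: 1.1 nM
- compound 2, `COc1ccc(/C=C(/F)c2cc(OC)c(OC)c(OC)c2)cc1[N+](=O)[O-]`: 42.6 nM
- compound 3, `COc1ccc(/C(F)=C(/F)c2cc(OC)c(OC)c(OC)c2)cc1O`: 3 nM

All three were tested in a functional assay on NCI-H460 cells (Homo sapiens) for cytotoxicity, read by sulforhodamine B assay, with a stated time of 72 h; a lower number here means a stronger inhibitor, a higher number a weaker inhibitor. Compound 1 gives 1.1 nM in this assay, the lowest of the three numbers. Compound 2 differs from compound 1 in a single place, (nitro in place of hydroxy on an aromatic carbon), and in this assay compound 2 gives 42.6 nM. That single change made a large step, a 39-fold higher number from compound 1 to compound 2 (1.59 log units; beyond the scatter).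

Compound 3 gives 3 nM in this assay. The difference between the core of compound 3 and the core of compound 1 is not broken down here. Compound 4, `COc1ccc(/C(F)=C(/F)c2cc(OC)c(OC)c(OC)c2)cc1[N+](=O)[O-]`, has not yet been measured. It differs from compound 3 by nitro in place of hydroxy on an aromatic carbon. Within the data shown here, the surroundings of the place are the same in both pairs, so this is the same change as the one from compound 1 to compound 2, made on a second core.

The expectation for compound 4 rests on a single earlier case, the pair of compound 1 and compound 2. In this assay the step is expected to be about as large, namely a 33-fold higher number from compound 3 to compound 4 (1.52 log units; beyond the scatter), because the same change gave a 39-fold higher number from compound 1 to compound 2 (1.59 log units; beyond the scatter). Compound 4 is therefore estimated at 100 nM in this assay. Given that one pair is a thin basis, compound 4 is expected to fall between 30 nM and 400 nM.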

Compound 4, half-maximal inhibitory concentration: 1170 nM
Compound 4: middle estimate off by 12-fold (1.07 log units), on the low side; the measured number lies above the stated range.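

Putting nitro in place of hydroxy on an aromatic carbon raises the number on both cores, and in this assay the new case is large, with a 390-fold higher number from compound 3 to compound 4 (2.59 log units; beyond the scatter). So the direction of the change carried over to the second core, but its size did not, and a step measured on one core was a poor guide to the exact size of the step on the other: the same change on two cores in this assay, a 39-fold higher number (1.59 log units; beyond the scatter) from compound 1 to compound 2 and a 390-fold higher number (2.59 log units; beyond the scatter) from compound 3 to compound 4, 10-fold (1.00 log units) apart, beyond the scatter of two such steps. These two pairs show only that the loss can be much greater on one core than on the other; they do not explain why the size differs, and they give no rule for how the same change would behave on any further core.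

The compounds shown leave open how other groups at this same place would compare with hydroxy and nitro, for example an amine or a carboxylic acid, and whether such groups would also give steps of different size on the two cores. They also leave open whether the gap between the two steps would persist in a cell line other than the one used here, since all four numbers come from a single assay.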